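Adding a Methoxy Group to Compound 2

The source may report more compounds than this note shows. Statements on the series, on what has been measured and on what is new or still open speak of the compounds shown alone.

Measured in a functional assay on DU-145 cells (Homo sapiens) for cytotoxicity, read by MTT assay, with a stated time of 48 h; a lower number here means a stronger inhibitor, a higher number a weaker inhibitor:
- compound 1 `COc1cc(OC)c(/C=C/C(=O)/C=C/c2cc3ccccc3nc2Cl)c(OC)c1`: > 10000 nM
- compound 2 `COc1ccc(/C=C/C(=O)/C=C/c2cc3ccccc3nc2Oc2ccccc2)c(OC)c1`: > 10000 nM
- compound 3 `COc1ccc(/C=C/C(=O)/C=C/c2cc3ccccc3nc2Oc2ccccc2)cc1OC`: > 10000 nM

Each of these three entries is a limit of the assay and not a number. The measured set therefore sits at the limit of > 10000 nM in this assay, at which 3 of the 3 values shown sit, and compound 2 has no numerical position within it. Compound 2 gives only a limit, > 10000 nM.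

The next compound, compound 4 `COc1cc(OC)c(/C=C/C(=O)/C=C/c2cc3ccccc3nc2Oc2ccccc2)c(OC)c1`, has not yet been measured. It differs from compound 2 by one change: methoxy in place of hydrogen on an aromatic carbon. In words, a methoxy takes the place of a hydrogen on an aromatic carbon.

Among the compounds with values here, only one measured step links two of the compounds. It is a step that the two limits leave unreadable from compound 2 to compound 3, and it provides no size on which to base a forecast. It also concerns a different change from the one made here. Within the data shown here, no measured step therefore shows what this added methoxy does in this assay, and no direction can be drawn from the data.

The expectation rests on the limit shared by the three measured compounds, so compound 4 is expected to remain weak, most likely reported as a limit as well. The estimated change is a step that the limit leaves unreadable from compound 2 to compound 4, with no step beyond the scatter expected. Compound 4 is estimated at 15000 nM, within an expected range of 5000 nM to 45000 nM.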

Compound 4, half-maximal inhibitory concentration: > 10000 nM
Compound 4 gave a limit, no number (the forecaster's own chance of this, stated with the estimate: 75%); the middle value is on the limit's open side.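

Within the data shown here, compound 4 is reported only as a limit, as are compound 1 and compound 2 in this assay, and neither the step to compound 4 from compound 2 nor the one from compound 1 can be read. The compounds shown leave open what the added methoxy, or phenoxy in place of chloro, does to potency, since all remain at one value: the limit of > 10000 nM in this assay, at which 4 of the 4 values shown sit.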